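From Methyl to Fluoro: One Small Swap on Compound 2

The compounds below may be only part of what the source reports. "The series", "measured", "known", "first", "only" and "open" are said of these compounds alone.

- compound 1 `O=S(=O)(c1ccc(F)cc1)c1nc2ccccc2nc1N1CCCC1`: 12800 nM
- compound 2 `Cc1ccc(S(=O)(=O)c2nc3ccccc3nc2N2CCC(O)CC2)cc1`: 4050 nM

In a functional assay on HL-60 cells (Homo sapiens) for cytotoxicity, read by MTT assay, with a stated time of 72 h (a lower number here means a stronger inhibitor, a higher number a weaker inhibitor), compound 2 gives 4050 nM. This is the lower of the two numbers, so compound 2 is the stronger inhibitor, and its gap to compound 1 lies beyond the usual scatter.

The next molecule, compound 3 `O=S(=O)(c1ccc(F)cc1)c1nc2ccccc2nc1N1CCC(O)CC1`, keeps compound 2 intact except for one group: fluoro in place of methyl on an aromatic carbon, turning 4-methylphenyl into 4-fluorophenyl (fluoro in place of methyl on an aromatic carbon). Going by the values given here, no measured pair here differs by this change alone, so its effect cannot be read directly from the data. Compound 1 carries the same 4-fluorophenyl and gives 12800 nM, but it also differs from compound 3 elsewhere, so it tilts the expectation only slightly toward a higher number. The expected change is small, a 1.4-fold higher number from compound 2 to compound 3 (0.13 log units; within the scatter), and no shift beyond the scatter is anticipated. For compound 3 the estimated value is 5500 nM, with an expected range from 2300 nM to 13000 nM.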

Compound 3, half-maximal inhibitory concentration: 1450 nM
Compound 3: middle estimate off by 3.8-fold (0.58 log units), on the high side, and the stated range ends above it.
By their numbers in this assay, from the lowest: compound 3; then compound 2; then compound 1.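

Fluoro in place of methyl on an aromatic carbon, para to a large group, gives a clear change in this assay (a 2.8-fold lower number from compound 2 to compound 3 (0.45 log units; beyond the scatter)), so this exchange of one heavy atom for another, turning 4-methylphenyl into 4-fluorophenyl, is enough to move the result in favour of the fluoro compound. With 4-fluorophenyl held constant, a second single change, 4-hydroxypiperidin-1-yl in place of pyrrolidin-1-yl, also moves the number the same way (an 8.8-fold lower number from compound 1 to compound 3 (0.95 log units; beyond the scatter)), making compound 3 the strongest inhibitor of the three, with both of its steps beyond the scatter. No measurement shown here explains why either change lowers the number.

What a chloro group or a methoxy group on the same aromatic carbon would do remains open, since the compounds shown compare only methyl and fluoro there. On these data alone, it is also open whether the hydroxyl group of 4-hydroxypiperidin-1-yl matters in itself, which a comparison with plain piperidin-1-yl or with morpholin-4-yl could begin to address.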